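The source may report more compounds than this note shows. Statements on the series, on what has been measured and on what is new or still open speak of the compounds shown alone.

In a functional assay on SF-268 cells (Homo sapiens) for inhibition, read by sulforhodamine B assay, with a stated time of 48 h (on this read-out lower numbers stand for stronger inhibition of growth and higher numbers for weaker inhibition of growth), compound 2 `COc1ccc(CNc2nc3cc(N)cc(N)c3nc2-c2ccccc2)cc1OC` gives 60300 nM, the highest of the three numbers measured. Compound 1 `Nc1cc(N)c2nc(-c3ccccc3)c(Oc3ccc(Cl)c(Cl)c3)nc2c1` gives 52500 nM in this assay, within the scatter of compound 2, while compound 3 `COc1cc(CNc2nc3cc(N)cc(N)c3nc2-c2ccccc2)cc(OC)c1OC` gives 14100 nM. Compound 4 `COc1ccc(CNc2nc3cc(N)cc(N)c3nc2-c2ccccc2)cc1` differs from compound 2 by hydrogen in place of methoxy on an aromatic carbon. Among the measured compounds shown here, only one measured step bears on this change, and it runs the other way: a 4.3-fold lower number from compound 2 to compound 3 (0.63 log units; beyond the scatter), a methoxy added to the same ring lowering the number modestly. Taking a methoxy away might therefore be expected to raise the number somewhat, though it may also stay within the scatter. Compound 4 is accordingly estimated to give 75000 nM in this assay, within 35000 nM to 160000 nM, a step expected as a 1.2-fold higher number from compound 2 to compound 4 (0.09 log units; within the scatter).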

Compound 4, concentration for total growth inhibition: 21900 nM
For compound 4 the middle estimate is 3.4-fold (0.53 log units) above the measured one, and the stated range ends above it.
By their numbers in this assay, from the lowest: compounds 3 and 4 (each within the scatter of the next); then compounds 1 and 2 (each within the scatter of the next).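

Going from 3,4-dimethoxyphenyl to 4-methoxyphenyl brings a 2.8-fold lower number from compound 2 to compound 4 (0.44 log units; beyond the scatter) and so moves the number the same way as adding a methoxy does in a 4.3-fold lower number from compound 2 to compound 3 (0.63 log units; beyond the scatter). Among these three compounds the number therefore does not follow the count of methoxy groups on this ring, and compound 2 stands above both of its neighbours. Nothing given here accounts for this. On these data alone, what remains open is how a hydroxyl, a fluorine or an amine would behave at this ring carbon. The compounds shown also leave open whether the remaining methoxy of compound 4 matters.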